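Phenylsulfanyl for Phenethyl: What Compound 3 Should Show

The compounds below may be only part of what the source reports. "The series", "measured", "known", "first", "only" and "open" are said of these compounds alone.

Within the data shown here, compound 2 `COc1cc(OCc2cccc(CCc3ccccc3)c2)c2cc(-c3cn4nc(OC)sc4n3)oc2c1` stands alongside compound 1 `COc1cc(OCc2cccc(O)c2)c2cc(-c3cn4nc(OC)sc4n3)oc2c1`, the only other number so far: in an ADME assay on microsomes from liver (Homo sapiens) for metabolic stability, with a stated time of 10 min (a lower number here means that less of the compound is left, a higher number that more of the compound is left), compound 2 gives 99%, while compound 1 gives 97%, and the step of a number 2 percentage points higher from compound 1 to compound 2 (within the scatter) is within the scatter. Compound 3 `COc1cc(OCc2cccc(Sc3ccccc3)c2)c2cc(-c3cn4nc(OC)sc4n3)oc2c1` differs from compound 2 by phenylsulfanyl in place of phenethyl on an aromatic carbon. Among the measured compounds shown here, only that single step bears on this change, and it was within the scatter, so no step beyond the scatter is expected in this assay. Compound 3 is therefore expected to give 96%, between 86% and 100%. The step this estimate means is a number 3 percentage points lower from compound 2 to compound 3 (within the scatter).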

Compound 3, percent of the compound remaining: 80%
Compound 3: the middle estimate sits 16 percentage points above what was measured; the whole stated range lies above it.
By their numbers in this assay, from the lowest: compound 3; then compounds 1 and 2 (each within the scatter of the next).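

In this assay, phenylsulfanyl on this aromatic carbon, meta to a large group, brings steps beyond the scatter, with a number 19 percentage points lower from compound 2 to compound 3 (beyond the scatter) and a number 17 percentage points lower from compound 1 to compound 3 (beyond the scatter). The position therefore does not tolerate every group alike, which the hydroxy and phenethyl compounds alone could not show. Nothing available explains this loss. On these data alone, whether the sulfur link itself matters remains open. Phenoxy or benzyl, with an oxygen or a single carbon as the link, could separate that from the shorter chain between the two rings.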